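A few compounds are considered here, and "the series" means these few. Any claim that something is new, unique, unknown or untested is made for them only; others in the source may bear on it.

Compound 1 `O=C1/C(=C/c2ccc(F)cc2)CCC/C1=C\c1ccccc1[N+](=O)[O-]` and compound 3 `O=C1/C(=C/c2ccc(F)cc2)CCC/C1=C\c1cccc([N+](=O)[O-])c1` are built from the same atoms joined differently; the difference between the two cores is not broken down here. In a physicochemical assay for lipophilicity (a lower number here means a more polar compound, a higher number a more lipophilic compound), compound 1 gives 4.86 and compound 3 gives 5.07, two numbers that lie within the scatter of each other. Compound 2 `O=C1/C(=C/c2ccc(Cl)cc2)CCC/C1=C\c1ccccc1[N+](=O)[O-]` differs from compound 1 in a single place: chloro in place of fluoro on an aromatic carbon. In this assay compound 2 gives 5.38, so this exchange made a number 0.52 log units higher from compound 1 to compound 2 (beyond the scatter). Compound 4 `O=C1/C(=C/c2ccc(Cl)cc2)CCC/C1=C\c1cccc([N+](=O)[O-])c1` carries the same change, now made on compound 3: chloro in place of fluoro on an aromatic carbon. The place is described in the same words for both pairs, so the change can be taken as the same one. Because the earlier exchange made a number 0.52 log units higher from compound 1 to compound 2 (beyond the scatter), compound 4 is expected to come out near 5.59 in this assay. The expected step is a number 0.52 log units higher from compound 3 to compound 4 (beyond the scatter), resting only on that one earlier pair. Compound 4 is estimated to fall between 5.3 and 5.9.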

Compound 4, partition coefficient: 5.58
Beside the measured number, compound 4's estimate is 0.01 log units above it, and the stated range covers the measured number.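

In this assay the exchange of fluoro for chloro gave a number 0.51 log units higher from compound 3 to compound 4 (beyond the scatter) on one core and a number 0.52 log units higher from compound 1 to compound 2 (beyond the scatter) on the other, so the step kept its direction and much the same size when carried between these two cores. For the compounds shown here, this is still only two pairs sharing one exchange in one assay, which is enough to show that the step held here but not to establish a rule for other cores or for other exchanges on these cores. Nothing given here explains the size of the step or why it was carried over so closely.

The compounds shown have only fluoro or chloro at this place, so it remains open how an amine, a carboxylic acid or a longer chain on that aromatic carbon would read in this assay on either core. Going by these compounds, it also remains open whether the step from fluoro to chloro would stay the same on a third core.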